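Hydroxyethyl for Isopropyl on Two Amino Alcohol Chains

The source may hold more compounds than are shown below. What is called first, only, known or untested is meant among the compounds shown, and "the series" means these compounds.

Measured compounds:
compound 1 `CCCCCCCCCCCCCCC[C@@H](O)[C@@H](N)[C@@H](C)O`, 19000 nM
compound 2 `CCCCCCCCCCCCCCC[C@@H](O)[C@@H](N)C(C)C`, 21000 nM
compound 3 `CCCCCCCCC[C@@H](O)[C@@H](N)C(C)C`, 20000 nM

All three were tested in a functional assay on HeLa cells (Homo sapiens) for antiproliferative activity, read by sulforhodamine B assay, with a stated time of 48 h; on this read-out lower numbers stand for stronger inhibition of growth and higher numbers for weaker inhibition of growth. Compound 2 and compound 3 share one change, (hydrogen in place of hexyl on a saturated chain carbon, ten or more bonds along the chain from an oxygen on a saturated carbon), and their numbers sit within the scatter of each other. The change from compound 2 to compound 1 is 1-hydroxyethyl in place of isopropyl on a saturated chain carbon bound to an amine nitrogen and a saturated chain carbon, and it made a step of a 1.1-fold lower number from compound 2 to compound 1 (0.04 log units; within the scatter). Compound 4 `CCCCCCCCC[C@@H](O)[C@@H](N)[C@@H](C)O` has not been measured; it arises from compound 3 by 1-hydroxyethyl in place of isopropyl on a saturated chain carbon bound to an amine nitrogen and a saturated chain carbon, the same change at the same place. Because a 1.1-fold lower number from compound 2 to compound 1 (0.04 log units; within the scatter) stayed within the scatter, the step from compound 3 to compound 4 in this assay is expected to be about a 1.1-fold lower number from compound 3 to compound 4 (0.05 log units; within the scatter). Compound 4 is therefore estimated at 18000 nM, with a likely range from 9000 nM to 36000 nM.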

Compound 4, concentration for 50% growth inhibition: 17000 nM
Estimate against measurement, compound 4: 1.1-fold (0.02 log units) above; low and high end bracket the measured number.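

In this assay, 1-hydroxyethyl in place of isopropyl gave a 1.2-fold lower number from compound 3 to compound 4 (0.07 log units; within the scatter), and this step agrees with the one seen on the longer chain: the same change on two cores in this assay, a 1.1-fold lower number (0.04 log units; within the scatter) from compound 2 to compound 1 and a 1.2-fold lower number (0.07 log units; within the scatter) from compound 3 to compound 4, 1.1-fold (0.03 log units) apart, within the scatter of two such steps. Hydrogen in place of hexyl gave a 1.1-fold lower number from compound 1 to compound 4 (0.05 log units; within the scatter), and this change also carried over from one core to the other: the same change on two cores in this assay, a 1.1-fold lower number (0.02 log units; within the scatter) from compound 2 to compound 3 and a 1.1-fold lower number (0.05 log units; within the scatter) from compound 1 to compound 4, 1.1-fold (0.03 log units) apart, within the scatter of two such steps. Among these compounds, these steps all lie within the scatter, so the series shows only that neither change moved the number measurably on these cores, not that either has an effect of any real size that transfers, nor how either would behave on a different core.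

The compounds shown leave open whether an amine or a carboxylic acid in place of 1-hydroxyethyl would shift growth inhibition. They also leave open whether a longer chain would do so.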